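Fluoro step from compound 2 to compound 4

The source may report more compounds than this note shows. Statements on the series, on what has been measured and on what is new or still open speak of the compounds shown alone.

In a functional assay on MOLT-3 cells (Homo sapiens) for antiproliferative activity (on this read-out lower numbers stand for stronger inhibition and higher numbers for weaker inhibition), compound 2 `COc1cc(NC(=O)c2cccc(NC(=O)C(C)Br)c2)ccc1O` gives 510 nM, the higher of the two true numbers in the series. The nearest value is that of compound 3 `COc1ccc(NC(=O)c2cc(NC(=O)C(C)Br)ccc2F)cc1` at 250 nM, a gap beyond the scatter. Compound 1 `CCCCNC(=O)c1cccc(NC(=O)C(C)Br)c1` reads > 10000 nM, which is a limit of the assay and not a number. Compound 4 `COc1cc(NC(=O)c2cc(NC(=O)C(C)Br)ccc2F)ccc1O` follows from compound 2 by fluoro in place of hydrogen on an aromatic carbon. Among the compounds with values here, no measured pair isolates this change. A small move toward a lower number in this assay is expected, possibly none beyond the scatter, and compound 3 at 250 nM also carries fluoro. The expected change is a 1.7-fold lower number from compound 2 to compound 4 (0.23 log units; within the scatter). For compound 4 the estimated value is 300 nM, with an expected range of 110 nM to 800 nM.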

Compound 4, half-maximal inhibitory concentration: 850 nM
Compound 4: the middle estimate sits 2.8-fold (0.45 log units) below what was measured; the whole stated range lies below it.
By their numbers in this assay, from the lowest: compound 3; then compounds 2 and 4 (each within the scatter of the next). At a limit, above all of these: compound 1.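

In this assay, fluoro in place of hydrogen on an aromatic carbon, ortho to a large group and para to a ((1-bromoethyl)carbonyl)amino group, gives a 1.7-fold higher number from compound 2 to compound 4 (0.22 log units; within the scatter). Within the data shown here, this is the first reading that isolates the change, and it shows that this position accepts fluoro with no shift beyond the scatter. Nothing at hand gives a cause for this step.

As far as these compounds go, whether an amine or a nitrile at this position would move the number beyond the scatter stays open. From the compounds shown here alone, the effect of the same fluoro step on other cores also stays open.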